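Isopropyl for trifluoromethoxy on the aryl piperazine

The source may hold more compounds than are shown below. What is called first, only, known or untested is meant among the compounds shown, and "the series" means these compounds.

Two compounds of the series have numbers in a functional assay for antagonist activity at Alpha-1A adrenergic receptor (Oryctolagus cuniculus) (a lower number here means tighter binding, a higher number weaker binding), so far. Compound 1 `COc1ccccc1N1CCN(CCCNc2ncccc2C(=O)C2CC2)CC1` gives 0.501 nM in this assay. Compound 2 `CN(C)C(=O)c1cccnc1NCCCN1CCN(c2ccccc2OC(F)(F)F)CC1` gives 3.16 nM in this assay. Among the measured compounds shown here, compound 2 thus stands highest of the two numbers, and its only neighbour, compound 1, sits at the lower number; the gap between the two is beyond the scatter. The two compounds differ in more than one place, so no single step can be read from them.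

Compound 3 `CC(C)c1ccccc1N1CCN(CCCNc2ncccc2C(=O)N(C)C)CC1` is not yet measured in this assay. It keeps the core of compound 2 and changes one group: isopropyl in place of trifluoromethoxy on an aromatic carbon. The new group sits on an aromatic carbon of a six-membered aromatic ring of carbon only, ortho to a large group.

For the measured compounds named here, no measured pair shows the effect of this exchange, so the size of the step is uncertain. With compound 2 at 3.16 nM as the only anchor, compound 3 is expected to land close to it, the estimated step being a 1.0-fold higher number from compound 2 to compound 3 (0.01 log units; within the scatter), with no direction claimed beyond the scatter. Compound 3 is therefore estimated at 3.2 nM in this assay, within a range from 1 nM to 10 nM.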

Compound 3, dissociation constant: 0.398 nM
Compound 3: the middle estimate sits 8.0-fold (0.91 log units) above what was measured; the whole stated range lies above it.
By their numbers in this assay, from the lowest: compounds 3 and 1 (each within the scatter of the next); then compound 2.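

On the aromatic carbon ortho to a large group, the exchange of trifluoromethoxy for isopropyl gives the series its first single-place step, which in this assay amounts to a 7.9-fold lower number from compound 2 to compound 3 (0.90 log units; beyond the scatter). With the rest of the molecule held constant, the number at this position therefore depends on the group it carries, and an all-carbon isopropyl group is accepted there in place of the oxygen- and fluorine-bearing trifluoromethoxy group. Nothing available ties the step to any one difference between the two groups, whether the heavy-atom count or the hydrogen-bond acceptor that leaves with trifluoromethoxy.

The other steps among the three compounds cannot be read, since compound 1 differs from both compound 2 and compound 3 in more than one place. Going by these compounds, it remains open whether the same exchange gives a step of similar size with the cyclopropyl ketone of compound 1 in place of the dimethylamide, and how a tert-butyl group, a chlorine atom or a cyclopropyl group would read on this aromatic carbon.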